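The source may hold more compounds than are shown below. What is called first, only, known or untested is meant among the compounds shown, and "the series" means these compounds.

Among the measured compounds shown here, compound 1 `COc1cccc(OC2=C(Oc3cccc(OC)c3)C(=O)c3c(OC)ccc(OC)c3C2=O)c1` is one of only two compounds with a measured number in a functional assay on HL-60 cells (Homo sapiens) for cytotoxicity; a lower number here means a stronger inhibitor, a higher number a weaker inhibitor. In this assay compound 1 gives 160 nM. The other measured compound is compound 2 `O=C1C=CC(=O)c2c(O)c(Oc3ccccc3)c(Oc3ccccc3)c(O)c21`, which in this assay gives 130 nM. These two numbers lie within the usual scatter of repeated measurements of each other, so the data do not tell the two compounds apart, and neither can be called the stronger or the weaker inhibitor. For the measured compounds named here, no pair of measured compounds differs in a single place, so there is no measured step to lean on.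

Compound 3 `COc1cccc(OC2=C(Cl)C(=O)c3c(OC)ccc(OC)c3C2=O)c1` has not yet been measured. It differs from compound 1 by one change: chloro in place of 3-methoxyphenoxy on a double-bonded ring carbon of the shared core. Going by the values given here, with no measured step of this kind available, the step from compound 1 to compound 3 is expected to be a 1.2-fold lower number from compound 1 to compound 3 (0.09 log units; within the scatter), small and not clearly beyond the scatter in either direction. Compound 3 is accordingly estimated at 130 nM in this assay, with a range from 40 nM to 400 nM.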

Compound 3, half-maximal inhibitory concentration: 440 nM
For compound 3 the middle estimate is 3.4-fold (0.53 log units) below the measured one; the measured number lies above the stated range.
By their numbers in this assay, from the lowest: compounds 2 and 1 (each within the scatter of the next); then compound 3.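

In this assay, chloro in place of 3-methoxyphenoxy on a double-bonded ring carbon gives a 2.8-fold higher number from compound 1 to compound 3 (0.44 log units; beyond the scatter), the first measured sign that the number depends on what this position carries. The step is modest for an exchange of a group of 9 heavy atoms with an aromatic ring for a single chlorine, and compound 3 still gives 440 nM, so the full 3-methoxyphenoxy group at this position is not required for a nanomolar number in this cell assay. Nothing available explains what about the exchange produces this step.

With chloro as the only replacement shown, the step cannot separate the effect of adding chloro from the effect of losing the 3-methoxyphenoxy group. An unsubstituted phenoxy group, a methoxy group, a methyl group or an amine such as morpholine at this same ring carbon would show whether the aromatic ring, the ether oxygen or the methoxy group on that ring accounts for the difference.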